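A few compounds are considered here, and "the series" means these few. Any claim that something is new, unique, unknown or untested is made for them only; others in the source may bear on it.

Compound 1 `CCOCCOn1c(-c2cccc(C#N)c2)nc(C)c1C(=O)OCC` gives 6250 nM
Compound 2 `CCOC(=O)c1c(C)nc(-c2cccc(C#N)c2)n1OCc1ccncc1` gives 6200 nM
Compound 3 `CCOC(=O)c1c(C)nc(-c2cccc(C#N)c2)n1OCc1ccc(F)cc1` gives 5880 nM

All three values come from a functional assay on a cell-free system (plasma, Oryctolagus cuniculus) for inhibition, with stated times of 5 min, 1 min and 6 min (a higher number here means a weaker inhibitor, a lower number a stronger inhibitor), and lie within the scatter of one another, so compound 3 stands level with compound 1 and compound 2. Compound 4 `CCOC(=O)c1c(C)nc(-c2cccc(C#N)c2)n1OCc1ccc(OC)cc1` has methoxy in place of fluoro compared with compound 3 methoxy in place of fluoro on an aromatic carbon on an aromatic carbon, para to a large group. The measured swaps further out on the chain gave a 1.0-fold lower number from compound 1 to compound 2 (0.00 log units; within the scatter), a 1.1-fold lower number from compound 1 to compound 3 (0.03 log units; within the scatter) and a 1.1-fold lower number from compound 2 to compound 3 (0.02 log units; within the scatter), so this series has moved little so far. Within the data shown here, no measured pair tests the fluoro swap directly, which keeps the range wide. The expected change in this assay is none beyond the scatter, an estimated 1.0-fold higher number from compound 3 to compound 4 (0.01 log units; within the scatter) here. For compound 4 the expected value is 6000 nM, with an estimated range from 3000 nM to 12000 nM.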

Compound 4, half-maximal inhibitory concentration: 6830 nM
For compound 4 the middle estimate is 1.1-fold (0.06 log units) below the measured one; the range from low to high includes it.
By their numbers in this assay, from the lowest: compounds 3, 2, 1 and 4 (each within the scatter of the next).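

In this assay, among these compounds, the step from fluoro to methoxy, on an aromatic carbon para to a large group, is the first change made on the aromatic ring itself, and it gives a 1.2-fold higher number from compound 3 to compound 4 (0.07 log units; within the scatter) without moving the number beyond the scatter. Against the other groups at this place it gives a 1.1-fold higher number from compound 2 to compound 4 (0.04 log units; within the scatter) and also a 1.1-fold higher number from compound 1 to compound 4 (0.04 log units; within the scatter) so all four compounds remain level. Nothing measured here accounts for this flat result.

Going by these compounds, whether an amine or a carboxylic acid on that ring carbon would shift the number remains open, as does the effect of a longer chain.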